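Removing the Methoxy Group: Compound 1 to Compound 4

The source may hold more compounds than are shown below. What is called first, only, known or untested is meant among the compounds shown, and "the series" means these compounds.

Measured so far:
Compound 1, `COc1ccc(-c2ccc(-c3ccc(C(=N)N)o3)o2)cc1`, gives 1880 nM.
Compound 2, `N=C(N)c1ccc(-c2ccc(-c3ccc(Cl)cc3)s2)s1`, gives 1850 nM.
Compound 3, `N=C(N)c1ccc(-c2ccc(-c3cncc4ccccc34)s2)s1`, gives 1680 nM.

All three values come from a functional assay on NCI/ADR-RES cells (Homo sapiens) for inhibition, read by sulforhodamine B assay, with a stated time of 48 h; a higher number here means a weaker inhibitor of growth, a lower number a stronger inhibitor of growth. Compound 1 sits at the upper end of the three numbers, but compound 2 and compound 3 both lie within the usual scatter of it, so the three compounds cannot be told apart on these data, and none of them can be called the stronger or the weaker inhibitor of growth.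

Compound 4, `N=C(N)c1ccc(-c2ccc(-c3ccccc3)o2)o1`, has not been measured. It differs from compound 1 in one place: hydrogen in place of methoxy on an aromatic carbon. Nothing else in the structure moves.

Going by the values given here, no step between two measured compounds is available to say how this change has behaved in this assay before, and the two other measured compounds differ from compound 1 in more than one place, so they give no direct guide. The expectation for the step from compound 1 to compound 4 is therefore small, with no clear direction, and most likely within the scatter. On that basis compound 4 is estimated at 2000 nM, with a range from 900 nM to 4500 nM, which amounts to an expected step of a 1.1-fold higher number from compound 1 to compound 4 (0.03 log units; within the scatter).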

Compound 4, concentration for 50% growth inhibition: 2820 nM
For compound 4 the middle estimate is 1.4-fold (0.15 log units) below the measured one, within the range that was stated.
By their numbers in this assay, from the lowest: compounds 3, 2, 1 and 4 (each within the scatter of the next).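

Going by these compounds alone, this is the first step between two measured compounds that differ in one place, and in this assay it reads a 1.5-fold higher number from compound 1 to compound 4 (0.18 log units; within the scatter) and so lies within the scatter. Hydrogen in place of methoxy on an aromatic carbon, para to a large group, therefore gives no change that can be told apart in this read-out, and the methoxy group is not shown to be needed for the growth inhibition seen with compound 1. No measurement of any property of either group accompanies this result, and the size of the step stays unexplained.

Within the data shown here, the single step covers only methoxy and hydrogen, so it remains open whether another group at this place, such as an amine, a hydroxyl group, a carboxylic acid or a longer alkoxy chain, would move the number beyond the scatter in either direction. As far as these compounds go, it also remains open whether the same change would behave alike on the core of compound 2 or compound 3, as both differ from compound 1 in more than one place.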